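A few compounds are considered here, and "the series" means these few. Any claim that something is new, unique, unknown or untested is made for them only; others in the source may bear on it.

Working notes on a small series built on a shared core, read in an ADME assay on microsomes from liver (Homo sapiens); on this read-out higher numbers stand for a more stable compound and lower numbers for a less stable compound. Compound 1 (`C[C@H]1CN(c2cc(-c3cc(C(F)(F)F)c4c(N)ncnn34)ccc2C#N)C(=O)C(C)(C)O1`) gives 85%, compound 2 (`C[C@@H]1CN(c2cc(-c3cc(Cl)c4c(N)ncnn34)ccc2C#N)C(=O)C(C)(C)O1`) gives 61% and compound 3 (`CC[C@H]1COC(C)(C)C(=O)N1c1cc(-c2cc(Cl)c3c(N)ncnn23)ccc1C#N`) gives 53%. Compound 2 therefore lies within the scatter of compound 3, while compound 1 stands higher than both, beyond the scatter.

The next compound to be read is compound 4 (`C[C@H]1CN(c2cc(-c3cc(Cl)c4c(N)ncnn34)ccc2C#N)C(=O)C(C)(C)O1`). Against compound 2 the change is the two compounds have the same atoms and bonds and differ only in configuration as drawn: 1 of 1 stereo elements differ; a stereocentre at a saturated ring carbon is drawn R in compound 2 and S in compound 4: a stereocentre at a saturated ring carbon is drawn R in compound 2 and S in compound 4. Among the measured compounds shown here, no measured pair differs in configuration alone, so the data give no direct size for a step of this kind. The best available anchor is compound 2 at 61%, since atoms and bonds stay the same.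

No shift beyond the scatter is expected in this assay, and neither direction is favoured. The expected a number 1 percentage points lower from compound 2 to compound 4 (within the scatter) is small and stays within the scatter. Going by these compounds, the range is kept wide because this kind of change remains untested. Compound 4 is estimated at 60%, with an expected range of 42% to 78%.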

Compound 4, percent of the compound remaining: 18%
For compound 4 the middle estimate is 42 percentage points above the measured one; the measured number lies below the stated range.
By their numbers in this assay, from the lowest: compound 4; then compounds 3 and 2 (each within the scatter of the next); then compound 1.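

The configuration at this saturated ring carbon proves to be a large lever on its own in this assay, with a number 43 percentage points lower from compound 2 to compound 4 (beyond the scatter), and this step can be assigned to the stereocentre alone because of one fact: the fact that compounds 2 and 4 differ only in the configuration as drawn. With the S drawing held, the aromatic substituent also proves to matter, with a number 67 percentage points lower from compound 1 to compound 4 (beyond the scatter) for chloro in place of trifluoromethyl on an aromatic carbon. The series therefore now holds two single-place changes that each move the read-out beyond the scatter, one in configuration and one in the aromatic substituent.

Going by these compounds, it remains open whether the stereocentre carries the same weight when trifluoromethyl rather than chloro sits on the aromatic carbon, so the two steps cannot yet be treated as independent of each other. Also open, on these data alone, is how a bromo or a methoxy group on that aromatic carbon would read in this assay, and whether an isopropyl group at the saturated ring carbon would show a similar dependence on configuration.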